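The source may report more compounds than this note shows. Statements on the series, on what has been measured and on what is new or still open speak of the compounds shown alone.

Compound 1 `COc1cc2c(Oc3ccc(NC(=O)c4nn(-c5cccc(F)c5)c(=O)c5ccccc45)cc3F)ccnc2cc1OCCCN1CCCC1` gives 190 nM in a functional assay on NCI-H460 cells (Homo sapiens) for cytotoxicity, read by MTT assay, with a stated time of 72 h; a higher number here means a weaker inhibitor, a lower number a stronger inhibitor.
Compound 2 `COc1cc2c(Oc3ccc(NC(=O)c4nn(-c5ccccc5F)c(=O)c5ccccc45)cc3F)ccnc2cc1OCCCN1CCCC1` gives 230 nM in this assay.
Compound 3 `COc1ccc(-n2nc(C(=O)Nc3ccc(Oc4ccnc5cc(OCCCN6CCCC6)c(OC)cc45)c(F)c3)c3ccccc3c2=O)cc1` gives 1650 nM in this assay.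

Compound 2 stands second highest of the three numbers in this assay. The step of a 1.2-fold higher number from compound 1 to compound 2 (0.08 log units; within the scatter) is within the scatter, so compounds 1 and 2 are not separated, whereas a 7.2-fold higher number from compound 2 to compound 3 (0.86 log units; beyond the scatter) and an 8.7-fold higher number from compound 1 to compound 3 (0.94 log units; beyond the scatter) are beyond it.

Compound 4 `COc1cc2c(Oc3ccc(NC(=O)c4nn(-c5ccccc5F)c(=O)c5ccccc45)cc3F)ccnc2cc1OCCCN1CCN(C)CC1` differs from compound 2 in one place: 4-methylpiperazin-1-yl in place of pyrrolidin-1-yl on a saturated chain carbon, three bonds along the chain from an oxygen on an aromatic ring. None of the three measured steps bears on this change; each of them alters the aryl group on the aromatic nitrogen and leaves the chain end untouched. The data therefore give no ground for expecting a step beyond the scatter in either direction in this assay, and the estimate for compound 4 is simply anchored on compound 2 with a widened range to admit the uncertainty.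

Compound 4 is estimated to give 240 nM in this assay, with a range from 90 nM to 650 nM. The expected step is a 1.0-fold higher number from compound 2 to compound 4 (0.02 log units; within the scatter).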

Compound 4, half-maximal inhibitory concentration: 230 nM
The estimate for compound 4 lay 1.0-fold (0.02 log units) above the measured number; low and high end bracket the measured number.
By their numbers in this assay, from the lowest: compounds 1, 2 and 4 (each within the scatter of the next); then compound 3.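

Going by these compounds alone, compound 4 brings the chain end into this assay for comparison, whereas the earlier compounds differed only in the aryl group on the aromatic nitrogen. With 2-fluorophenyl held in place, replacing pyrrolidin-1-yl with 4-methylpiperazin-1-yl on a saturated chain carbon gives no change at the digits printed from compound 2 to compound 4 (within the scatter), so in this single pair a six-membered ring with two hetero atoms reads the same as a five-membered ring with one. Nothing measured here accounts for the two end groups reading alike.

The compounds shown leave open whether a morpholine ring, a dimethylamino group or a carboxylic acid at the chain end, or a shorter or longer chain, would read the same. They also leave open whether this swap gives the same result with 4-methoxyphenyl on the aromatic nitrogen.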